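Acetamido for Methyl on the Aryl Ring of Compound 3

A few compounds are considered here, and "the series" means these few. Any claim that something is new, unique, unknown or untested is made for them only; others in the source may bear on it.

Compound 3 `CCOC(=O)c1c(-c2cccc(C)c2)csc1N` stands highest of the three compounds measured in an assay on isolated protein for inhibition of protein kinase C zeta type (Homo sapiens), with stated times of 1 h and 2.5 min, tested at 30 uM (a lower number here means less inhibition, a higher number more inhibition at the concentration tested (going by the name of the read-out)), where compound 3 gives 77%. Compound 1 `CCOC(=O)c1c(-c2ccc(OC)c(OC)c2)csc1N(C)C` gives 60%, and compound 2 `CCOC(=O)c1c(-c2ccc(OC)c(OC)c2)csc1NC(N)=O` gives 14%. For the measured compounds named here, the one step between measured compounds, a number 46 percentage points lower from compound 1 to compound 2 (beyond the scatter), changed a group on the shared core rather than on the six-membered aromatic ring of carbon only, so it bears only loosely on the change to compound 4 `CCOC(=O)c1c(-c2cccc(NC(C)=O)c2)csc1N`, in which (acetamido in place of methyl on an aromatic carbon). That single step fell steeply, and it is the only hint available of what a change of this kind does here. A moderate fall, smaller than that step, is therefore expected for compound 4 in this assay, a number 27 percentage points lower from compound 3 to compound 4 (beyond the scatter). Compound 4 is estimated at 50%, with a range from 25% to 75%.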

Compound 4, a percentage reported as inhibition, at one concentration (the size of the read-out at that concentration, not a potency): 89%
Compound 4: the middle estimate sits 39 percentage points below what was measured; measured number outside the range, above it.
By their numbers in this assay, from the lowest: compound 2; then compound 1; then compound 3; then compound 4.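

In this assay, the step on the aryl ring is a number 12 percentage points higher from compound 3 to compound 4 (beyond the scatter), so this aromatic carbon, meta to a large group, accepts acetamido in place of methyl without loss. The steep fall seen on the shared core with ureido thus does not carry over to this position. No measurement available here accounts for the rise. The compounds shown leave open whether an amine or a carboxylic acid on this same carbon, or a chain longer than acetamido, would keep the number this high.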